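Methoxy to hydroxy on a series resting at its limit

This account rests on a few compounds, and the source may have more. Where it says the series, first, only, none or still open, it means among the compounds named here.

Measured in a functional assay on KYSE-70 cells for antiproliferative activity against KYSE-70 cell line (Homo sapiens), read by MTT assay, with a stated time of 72 h; a lower number here means a stronger inhibitor, a higher number a weaker inhibitor:
compound 1 `O=C(Nc1cc(F)cc(F)c1)c1cc(=O)[nH]c2cc(F)ccc12`: > 20000 nM (a limit)
compound 2 `O=C(Nc1cc(F)cc(F)c1)c1cc(=O)[nH]c2cc(C(F)(F)F)ccc12`: 14200 nM
compound 3 `COc1ccc2c(C(=O)Nc3cc(F)cc(F)c3)cc(=O)[nH]c2c1`: > 20000 nM (a limit)

Compound 3 stands at a limit and not at a number: > 20000 nM. The series mostly rests at the limit of > 20000 nM in this assay, at which 2 of the 3 values shown sit. The next compound, compound 4 `O=C(Nc1cc(F)cc(F)c1)c1cc(=O)[nH]c2cc(O)ccc12`, differs by one change: hydrogen in place of methyl on an oxygen on an aromatic ring, that is, methoxy to hydroxy, with hydrogen in place of methyl on an oxygen on an aromatic ring.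

Among the compounds with values here, no measured step makes this same change. The nearest steps exchange groups on an aromatic carbon: an at least 1.4-fold lower number from compound 1 to compound 2 (0.14 log units; that floor lies within the scatter), an at least 1.4-fold higher number from compound 2 to compound 3 (0.14 log units; that floor lies within the scatter) and a step that the two limits leave unreadable from compound 1 to compound 3. None of these is readable as a step beyond the scatter, so no step beyond the scatter is expected in this assay, in either direction. The expected step is a number no higher from compound 3 to compound 4 (the limit leaves the size open). Compound 4 is estimated at 20000 nM, with an expected range of 9000 nM to 40000 nM.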

Compound 4, half-maximal inhibitory concentration: > 20000 nM
Compound 4: a limit, no number; the forecaster's own chance of this, stated with the estimate: 70%; the middle value lies on the limit itself.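

In this assay compound 4 gives > 20000 nM, a limit and not a number. Hydroxy therefore sits with fluoro and methoxy at this position, the change from methoxy to hydroxy yields no number, and the steps to compound 4 from the two other limits cannot be read. Against trifluoromethyl, the only group here with a number, the result reads as an at least 1.4-fold higher number from compound 2 to compound 4 (0.14 log units; that floor lies within the scatter), so the position still shows no difference beyond the scatter and the series stays at one value: the limit of > 20000 nM in this assay, at which 3 of the 4 values shown sit.

On these data alone, whether an amine or a carboxylic acid at this position would give a number clear of the limit stays open. Also open, as far as these compounds go, is whether any group here can move the series beyond the scatter at all.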